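Variation on the chain carbon bound to the aromatic nitrogen

The source may report more compounds than this note shows. Statements on the series, on what has been measured and on what is new or still open speak of the compounds shown alone.

Measured so far in an assay on isolated protein (Oryctolagus cuniculus) with Thromboxane-A synthase (Homo sapiens) as the target, tested at 1 uM; a higher number here means more inhibition at the concentration tested (going by the name of the read-out), a lower number less inhibition:
compound 1 `CCCCn1nc(-c2cccnc2)c2ccccc2c1=O`: 91%
compound 2 `CCCCCCCCn1nc(-c2cccnc2)c2ccccc2c1=O`: 99%
compound 3 `O=c1c2ccccc2c(-c2cccnc2)nn1Cc1cccc(Cl)c1`: 95%

Compound 3 stands second highest of the three numbers; its nearest neighbour is compound 1 at a number 4 percentage points higher from compound 1 to compound 3 (within the scatter), its furthest compound 2 at a number 4 percentage points lower from compound 2 to compound 3 (within the scatter), and both of these steps lie within the scatter. The next compound, compound 4 `O=c1c2ccccc2c(-c2cccnc2)nn1CCSc1ncccn1`, again changes the group at the same place: ((pyrimidin-2-yl)sulfanyl)methyl in place of 3-chlorophenyl on a saturated chain carbon bound to an aromatic nitrogen. The two measured steps that altered this position bear on it, and neither moved the number beyond the scatter, so no step beyond the scatter is expected here either; the expected step is a number 2 percentage points lower from compound 3 to compound 4 (within the scatter). Compound 4 is therefore expected to give about 93% in this assay, estimated between 80% and 99%.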

Compound 4, a percentage reported as inhibition, at one concentration (the size of the read-out at that concentration, not a potency): 86%
The estimate for compound 4 lay 7 percentage points above the measured number, within the range that was stated.
By their numbers in this assay, from the lowest: compounds 4, 1, 3 and 2 (each within the scatter of the next, the first and the last beyond it).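

In this assay this position now gives its first step beyond the scatter, a number 13 percentage points lower from compound 2 to compound 4 (beyond the scatter), though a modest one. The ((pyrimidin-2-yl)sulfanyl)methyl group stays within the scatter in the other two comparisons, a number 9 percentage points lower from compound 3 to compound 4 (within the scatter) and a number 5 percentage points lower from compound 1 to compound 4 (within the scatter), so the position accepts a ring with hetero atoms and hydrogen-bond acceptors without a clear separation from those two compounds. Nothing measured here explains the step.

On these data alone, whether an amine or a carboxylic acid at this position would keep inhibition this high remains open. With one concentration only, the numbers give no ranking of potency.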